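This account rests on a few compounds, and the source may have more. Where it says the series, first, only, none or still open, it means among the compounds named here.

Values in a functional assay on HeLa cells (Homo sapiens) for cytotoxicity, read by MTT assay, with a stated time of 72 h; a lower number here means a stronger inhibitor, a higher number a weaker inhibitor:
compound 1 `O=C(/C=C/c1cccc(Cl)c1Cl)Nc1cc2c(Nc3ccc(F)c(Cl)c3)ncnc2cc1O[C@H]1CCOC1`: 30500 nM
compound 2 `COc1cc(/C=C/C(=O)Nc2cc3c(Nc4ccc(F)c(Cl)c4)ncnc3cc2O[C@H]2CCOC2)cc(OC)c1OC`: 24500 nM
compound 3 `O=C(/C=C/c1cc(Br)c(O)c(Br)c1)Nc1cc2c(Nc3ccc(F)c(Cl)c3)ncnc2cc1O[C@H]1CCOC1`: 27700 nM

Compound 3, at 27700 nM, stands level with the other two compounds, and its value is separated from neither by more than the scatter. Compound 4 `COc1cc(/C=C/C(=O)Nc2cc3c(Nc4ccc(F)c(Cl)c4)ncnc3cc2O[C@H]2CCOC2)cc(OC)c1O` has not yet been measured in this assay. The structural change from compound 3 is 4-hydroxy-3,5-dimethoxyphenyl in place of 3,5-dibromo-4-hydroxyphenyl on a double-bonded chain carbon bound to a double-bonded chain carbon. In words, 4-hydroxy-3,5-dimethoxyphenyl takes the place of 3,5-dibromo-4-hydroxyphenyl on a double-bonded chain carbon bound to a double-bonded chain carbon.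

Among the measured compounds shown here, three measured steps bear on this, all of them exchanges at that same place: a 1.2-fold lower number from compound 1 to compound 2 (0.10 log units; within the scatter), a 1.1-fold lower number from compound 1 to compound 3 (0.04 log units; within the scatter) and a 1.1-fold higher number from compound 2 to compound 3 (0.05 log units; within the scatter). For the measured compounds named here, all three lie within the scatter, and no compound in this small set goes against that picture. Going by the values given here, none of the measured compounds carries the entering group, so the evidence is indirect and the range is kept wide.

No step beyond the scatter is expected in this assay, in either direction. The estimated step is a 1.1-fold lower number from compound 3 to compound 4 (0.03 log units; within the scatter). For compound 4 the expected value is 26000 nM, with an estimated range from 14000 nM to 45000 nM.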

Compound 4, half-maximal inhibitory concentration: 27400 nM
For compound 4 the middle estimate is 1.1-fold (0.02 log units) below the measured one; low and high end bracket the measured number.
By their numbers in this assay, from the lowest: compounds 2, 4, 3 and 1 (each within the scatter of the next).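

In this assay, 4-hydroxy-3,5-dimethoxyphenyl in place of 3,5-dibromo-4-hydroxyphenyl gives a 1.0-fold lower number from compound 3 to compound 4 (0.00 log units; within the scatter), so with the hydroxy group common to both, the pair of bromines and the pair of methoxy groups cannot be told apart at this position on the double-bonded chain carbon. The series now also has a step confined to one substituent on the phenyl ring: hydrogen in place of methyl on an oxygen on an aromatic ring gives a 1.1-fold higher number from compound 2 to compound 4 (0.05 log units; within the scatter), while 4-hydroxy-3,5-dimethoxyphenyl in place of 2,3-dichlorophenyl gives a 1.1-fold lower number from compound 1 to compound 4 (0.05 log units; within the scatter), which leaves all four compounds level, with none going against that reading. No independent data bear on why these values stand level.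

Going by these compounds, all four groups at this position are substituted phenyl rings, so it remains open whether the same level reading would hold for a phenyl ring carrying a dimethylamino group or a carboxylic acid, or for a pyridine ring in place of the phenyl ring. On these data alone, it is equally open whether a longer chain between the amide carbonyl and the ring would leave this assay just as flat.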